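A few compounds are considered here, and "the series" means these few. Any claim that something is new, unique, unknown or untested is made for them only; others in the source may bear on it.

Measured compounds:
Compound 1 `O=S(=O)(Nc1cccc2c1CCCC2c1c[nH]cn1)C1CC1`: 51%
Compound 2 `CC(C)S(=O)(=O)Nc1cccc2c1CCCC2c1c[nH]cn1`: 74%

In a functional assay on Urethra with Alpha-1A adrenergic receptor (Oryctolagus cuniculus) as the target (a lower number here means a smaller maximal response, a higher number a larger maximal response), compound 2 holds the higher of the two numbers shown; the single measured step, a number 23 percentage points higher from compound 1 to compound 2 (beyond the scatter), separates it from compound 1 and lies beyond the scatter, though it is only modest in size.

Compound 3 `CCS(=O)(=O)Nc1cccc2c1CCCC2c1c[nH]cn1` is next. It differs from compound 2 by hydrogen in place of methyl on a saturated chain carbon bound to a saturated chain carbon and a sulfonyl sulfur. Going by the values given here, the one measured step bears on it only loosely: that step also altered the group on the sulfonyl sulfur, but by a different exchange, so its direction cannot be carried over with confidence. Removing a methyl from the chain is a smaller alteration than the measured one, and a downward step that is expected to be smaller than the measured one is the working expectation, written as a number 12 percentage points lower from compound 2 to compound 3 (beyond the scatter).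

For compound 3 in this assay the estimate is 62%, with a range from 45% to 82%.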

Compound 3, largest response reached (reported as efficacy), in percent of the reference or control that the assay uses: 71%
Beside the measured number, compound 3's estimate is 9 percentage points below it, and the stated range covers the measured number.
By their numbers in this assay, from the lowest: compound 1; then compounds 3 and 2 (each within the scatter of the next).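

In this assay, hydrogen in place of methyl on this chain carbon gives a number 3 percentage points lower from compound 2 to compound 3 (within the scatter), so isopropyl and ethyl on the sulfonyl sulfur cannot be told apart here. Ethyl in place of cyclopropyl gives a number 20 percentage points higher from compound 1 to compound 3 (beyond the scatter), which places ethyl with isopropyl, whose step is a number 23 percentage points higher from compound 1 to compound 2 (beyond the scatter); among these three compounds, only compound 1, the cyclopropyl member, stands apart from the other two. No evidence shown accounts for this separation.

Going by these compounds, whether the smaller methyl group or a longer chain such as n-butyl on the sulfonyl sulfur stays with compound 2 and compound 3 remains open. Also open, on these data alone, is whether a ring other than cyclopropyl, such as cyclobutyl, falls nearer to compound 1 at 51%.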